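Heteroaryl Exchange on a Chlorinated Aryl Ring in Hydrolase Inhibitors

A few compounds are considered here, and "the series" means these few. Any claim that something is new, unique, unknown or untested is made for them only; others in the source may bear on it.

Compound 1: `Cn1cc(-c2ccc(CN3CCC(O)(Cn4cnc5c(-c6ccc(CN)cc6)n(C)nc5c4=O)CC3)c(Cl)c2)cn1` — in an assay on isolated protein for inhibition of ubiquitin carboxyl-terminal hydrolase 7 (Homo sapiens), with stated times of 30 min and 2 h (on this read-out higher numbers stand for weaker inhibition and lower numbers for stronger inhibition), compound 1 gives 291 nM
Compound 2: `Cn1nc2c(=O)n(CC3(O)CCN(Cc4ccc(-n5cccn5)cc4Cl)CC3)cnc2c1-c1ccc(CN)cc1` — in this assay compound 2 gives 233 nM
Compound 3: `Cn1nc2c(=O)n(CC3(O)CCN(Cc4ccc(-c5cccs5)cc4Cl)CC3)cnc2c1-c1ccc(CN)cc1` — awaiting measurement in this assay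

Of the compounds shown here, two have been measured so far. Compound 2 stands at 233 nM in this assay, and compound 1 stands at 291 nM; the two numbers lie within the scatter of each other, so neither can be called the more potent. Among the measured compounds shown here, the one measured step, a 1.2-fold lower number from compound 1 to compound 2 (0.10 log units; within the scatter), exchanged one five-membered heteroaryl group for another on the same aromatic carbon and left the read-out essentially where it was.

Compound 3 repeats this kind of exchange at the same place: thiophen-2-yl in place of 1H-pyrazol-1-yl on an aromatic carbon. For the measured compounds named here, the only step that bears on it is the one from compound 1 to compound 2, which was within the scatter, so no movement beyond the scatter is expected in this assay for compound 3 either. The expected step is a 1.1-fold higher number from compound 2 to compound 3 (0.03 log units; within the scatter). Compound 3 is therefore estimated at 250 nM, with a range from 100 nM to 650 nM.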

Compound 3, half-maximal inhibitory concentration: 38.6 nM
For compound 3 the middle estimate is 6.5-fold (0.81 log units) above the measured one, and the stated range ends above it.
By their numbers in this assay, from the lowest: compound 3; then compounds 2 and 1 (each within the scatter of the next).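

The position on the aromatic carbon para to a large group and meta to a chloro group proved sensitive to the choice of five-membered aromatic ring in this assay, with thiophen-2-yl giving a step beyond the scatter from either pyrazole group (a 6.0-fold lower number from compound 2 to compound 3 (0.78 log units; beyond the scatter); a 7.5-fold lower number from compound 1 to compound 3 (0.88 log units; beyond the scatter)). The earlier exchange between the two pyrazole groups (a 1.2-fold lower number from compound 1 to compound 2 (0.10 log units; within the scatter)) had given no hint of this, as it stayed within the scatter. Between compound 2 and compound 3 the count of 5 heavy atoms stays the same while one carbon and one sulfur replace two ring atoms of 1H-pyrazol-1-yl, so the heavy-atom count alone does not track the change, and nothing available explains why the number moved.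

These three compounds cannot separate a contribution of the sulfur atom from that of removing the ring nitrogens, and they do not show whether the attachment point on the thiophene matters. Thiophen-3-yl, furan-2-yl and a plain phenyl ring at this carbon would address those questions, while a small amine on the thiophene would test whether the ring tolerates further substitution.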